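Furan to Fluorophenyl on the Carbonyl of Compound 2

The source may report more compounds than this note shows. Statements on the series, on what has been measured and on what is new or still open speak of the compounds shown alone.

Of the compounds shown here, three have been measured in a functional assay on MCF7 cells (Homo sapiens) for cytotoxicity, read by MTT assay, with a stated time of 48 h; a lower number here means a stronger inhibitor, a higher number a weaker inhibitor. Compound 1 `COc1cc(-c2nnc3n2NC(c2cccs2)C(C(=O)c2ccc(F)cc2)S3)cc(OC)c1OC` gives 43700 nM. Compound 3 `COc1cc(-c2nnc3n2NC(c2ccco2)C(C(=O)c2cccc(Br)c2)S3)cc(OC)c1OC` gives 91800 nM. Compound 2 `COc1cc(-c2nnc3n2NC(c2ccco2)C(C(=O)c2ccco2)S3)cc(OC)c1OC` gives only a limit, > 100000 nM, so its number is not known; it sits at the limit of > 100000 nM in this assay, at which 1 of the 3 values shown sits.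

The unmeasured compound 4 `COc1cc(-c2nnc3n2NC(c2ccco2)C(C(=O)c2ccccc2F)S3)cc(OC)c1OC` differs from compound 2 in one place: 2-fluorophenyl in place of furan-2-yl on a carbonyl carbon. Within the data shown here, only one measured step bears on this kind of change, the exchange of the same furan-2-yl for 3-bromophenyl, which gave an at least 1.0-fold lower number from compound 2 to compound 3 (0.03 log units; that floor lies within the scatter). Compound 1 carries a 4-fluorophenyl on its carbonyl but also a thiophene in place of the furan, so its value stands beside that of compound 3 without forming a single-point comparison. Given a step that stayed within the scatter and a starting point known only as a limit, no change beyond the scatter is expected; compound 4 is expected to show an at least 1.2-fold lower number from compound 2 to compound 4 (0.09 log units; that floor lies within the scatter). The estimate for compound 4 is 80000 nM, between 30000 nM and 200000 nM.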

Compound 4, half-maximal inhibitory concentration: 94800 nM
Estimate against measurement, compound 4: 1.2-fold (0.07 log units) below; the measured number falls inside the stated range.
By their numbers in this assay, from the lowest: compound 1; then compounds 3 and 4 (each within the scatter of the next). At a limit, above all of these: compound 2.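

On the carbonyl carbon, the 2-fluorophenyl and the 3-bromophenyl cannot be told apart in this assay: the exchange between them gives a 1.0-fold higher number from compound 3 to compound 4 (0.01 log units; within the scatter). Against the furan-2-yl, the 2-fluorophenyl gives an at least 1.0-fold lower number from compound 2 to compound 4 (0.02 log units; that floor lies within the scatter), a floor that, like the one for the 3-bromophenyl, does not fix the real size of the step. The furan-2-yl on this carbonyl is still known only through a limit, so neither step can be sized: the limit of > 100000 nM in this assay, at which 1 of the 4 values shown sits.

On these data alone, compound 1 carries its 4-fluorophenyl together with a thiophene, so the effect of a 4-fluorophenyl on this carbonyl with the furan kept remains open. Also open, as far as these compounds go, is whether a different kind of group here, such as a simple methyl, a pyridine or a phenyl ring bearing a carboxylic acid, would move the number beyond the scatter.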